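The source may hold more compounds than are shown below. What is called first, only, known or untested is meant among the compounds shown, and "the series" means these compounds.

Three compounds share one core and were tested in a functional assay on CHO-K1 cells for antagonist activity at transient receptor potential cation channel subfamily V member 1 (Homo sapiens), read by FLIPR; on this read-out higher numbers stand for weaker inhibition and lower numbers for stronger inhibition. Compound 1 `Cc1ccc(Nc2nc(C(F)(F)F)ccc2CNC(=O)C(C)c2ccc(NS(C)(=O)=O)c(F)c2)cc1C` gives 1160 nM. Compound 2 `Cc1ccc(Cl)cc1Nc1nc(C(F)(F)F)ccc1CNC(=O)C(C)c1ccc(NS(C)(=O)=O)c(F)c1` gives 140 nM. Compound 3 `CC(C(=O)NCc1ccc(C(F)(F)F)nc1N1CC=CCC1)c1ccc(NS(C)(=O)=O)c(F)c1` gives 12.1 nM. Compound 3 therefore stands lowest of the three and is the strongest inhibitor here: the steps are a 12-fold lower number from compound 2 to compound 3 (1.06 log units; beyond the scatter) and a 96-fold lower number from compound 1 to compound 3 (1.98 log units; beyond the scatter), while between the other two there is an 8.3-fold lower number from compound 1 to compound 2 (0.92 log units; beyond the scatter).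

Compound 4 `CC(C(=O)NCc1ccc(C(F)(F)F)nc1N1CCC(O)CC1)c1ccc(NS(C)(=O)=O)c(F)c1` keeps the core of compound 3 and differs from it in one place: a group of 7 heavy atoms (5 carbon, 1 nitrogen, 1 oxygen; one six-membered non-aromatic ring with 1 hetero atom) in place of a group of 6 heavy atoms (5 carbon, 1 nitrogen; one six-membered non-aromatic ring with 1 hetero atom), on an aromatic carbon. The group that leaves carries one double bond outside aromatic rings and no hydrogen-bond donor; the 4-hydroxypiperidin-1-yl that enters carries one hydrogen-bond donor and two hydrogen-bond acceptors.

Among the compounds with values here, none of the measured steps touches this ring. All three exchange one aromatic amine for another or for this six-membered non-aromatic ring, so they say nothing direct about swapping one such ring for another. Within the data shown here, with no guiding step, the expectation is a small change, likely within the scatter, with a slight lean towards a higher number, so compound 4 is estimated at 20 nM, with a range from 6 nM to 70 nM. The expected step is a 1.7-fold higher number from compound 3 to compound 4 (0.22 log units; within the scatter).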

Compound 4, half-maximal inhibitory concentration: "not active" (no number reported)
The entry for compound 4 holds no number, and the estimate cannot be compared.
By their numbers in this assay, from the lowest: compound 3; then compound 2; then compound 1.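

In this assay, within the data shown here, compound 4 is recorded as "not active" with no number, so no step between compound 3 and compound 4 can be read. Nothing available here bears on this result. Left open is how far the 4-hydroxypiperidin-1-yl of compound 4 moves the number away from that of compound 3, at 12.1 nM.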